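This account rests on a few compounds, and the source may have more. Where it says the series, first, only, none or still open, it means among the compounds named here.

In a functional assay on CAKI-1 cells (Homo sapiens) for cytotoxicity, read by sulforhodamine B assay, with a stated time of 48 h (a lower number here means a stronger inhibitor of growth, a higher number a weaker inhibitor of growth), compound 1 `CC1=C(C(=O)Nc2ccc(Cl)c(Cl)c2)C(c2cccc(O)c2)NC(=S)N1` gives 22400 nM, the highest of the three numbers recorded. Compound 3 `CC1=C(C(=O)Nc2ccc(Cl)c(Cl)c2)C(c2ccccc2Cl)NC(=S)N1` gives 17800 nM, and a 1.3-fold lower number from compound 1 to compound 3 (0.10 log units; within the scatter). Compound 2 `CC1=C(C(=O)Nc2ccc(Cl)c(Cl)c2)C(c2cccc(Oc3ccccc3)c2)NC(=S)N1` gives 8510 nM, and a 2.6-fold lower number from compound 1 to compound 2 (0.42 log units; beyond the scatter). Compound 4 `CC1=C(C(=O)Nc2ccc(F)c(Cl)c2)C(c2cccc(O)c2)NC(=S)N1` differs from compound 1 by fluoro in place of chloro on an aromatic carbon. Neither measured step touches that part of the molecule: one alters the group on the oxygen and the other the group on the saturated ring carbon, so nothing measured shows how this exchange of halogens shifts the numbers in this assay. Compound 4 is therefore expected to remain within the scatter of compound 1, with a 1.1-fold higher number from compound 1 to compound 4 (0.05 log units; within the scatter). The estimate for compound 4 is 25000 nM, between 10000 nM and 60000 nM.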

Compound 4, concentration for 50% growth inhibition: 50100 nM
The estimate for compound 4 lay 2.0-fold (0.30 log units) below the measured number, and the stated range covers the measured number.
By their numbers in this assay, from the lowest: compound 2; then compounds 3 and 1 (each within the scatter of the next); then compound 4.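

In this assay, the printed step a 2.2-fold higher number from compound 1 to compound 4 (0.35 log units; beyond the scatter) shows that this position on the 3,4-dichlorophenyl group is not silent. Fluoro in place of chloro, para to a large group and ortho to a chloro group, weakens growth inhibition beyond the scatter, though only modestly. Nothing available explains this shift.

The compounds shown leave open whether the same exchange would shift the numbers similarly on the frameworks of compound 2 or compound 3. They also leave open how a bromo, methoxy or trifluoromethyl group would fare at this position.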